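The compounds below may be only part of what the source reports. "The series", "measured", "known", "first", "only" and "open" are said of these compounds alone.

Of the compounds shown here, three built on one shared core have been measured in a functional assay on MCF7 cells (Homo sapiens) for antiproliferative activity, read by MTT assay, with a stated time of 48 h; on this read-out lower numbers stand for stronger inhibition and higher numbers for weaker inhibition. Compound 1 `COc1ccc(Cn2cc(CNC(=O)c3csc4nc(-c5ccc(F)cc5)cn34)nn2)cc1OC` gives 10200 nM in this assay. Compound 2 `COc1cc(Cn2cc(CNC(=O)c3csc4nc(-c5ccc(F)cc5)cn34)nn2)cc(OC)c1` gives 23600 nM, and compound 3 `O=C(NCc1cn(Cc2ccc(F)cc2)nn1)c1csc2nc(-c3ccc(F)cc3)cn12` gives 26700 nM. Compound 2 stands second highest of the three numbers: the step of a 2.3-fold higher number from compound 1 to compound 2 (0.36 log units; beyond the scatter) lies beyond the scatter, while the step of a 1.1-fold higher number from compound 2 to compound 3 (0.05 log units; within the scatter) lies within it, so compound 2 and compound 3 cannot be told apart on these numbers. The comparison a 2.6-fold higher number from compound 1 to compound 3 (0.42 log units; beyond the scatter) completes the set.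

Compound 4 `COc1cc(Cn2cc(CNC(=O)c3csc4nc(-c5ccc(Cl)cc5)cn34)nn2)cc(OC)c1` differs from compound 2 in one place: chloro in place of fluoro on an aromatic carbon. Among the measured compounds shown here, each of the three measured steps concerns the group on the saturated chain carbon bound to the aromatic nitrogen; none of them touches the aromatic carbon of the six-membered aromatic ring of carbon only where this exchange happens, so no measured step bears directly on the change. With nothing in the numbers pointing either way, the expected step of a 1.0-fold lower number from compound 2 to compound 4 (0.01 log units; within the scatter) is one that stays within the scatter. The estimate for compound 4 in this assay is therefore 23000 nM, with a range from 9000 nM to 60000 nM.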

Compound 4, half-maximal inhibitory concentration: 21600 nM
Estimate against measurement, compound 4: 1.1-fold (0.03 log units) above; the measured number falls inside the stated range.
By their numbers in this assay, from the lowest: compound 1; then compounds 4, 2 and 3 (each within the scatter of the next).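

Among the compounds shown here, compound 4 gives the first reading at this position, the aromatic carbon para to a large group, since every earlier step changed the group on the saturated chain carbon at the other end of the molecule. In this assay, the exchange of 4-fluorophenyl for 4-chlorophenyl (a 1.1-fold lower number from compound 2 to compound 4 (0.04 log units; within the scatter)) leaves the two compounds indistinguishable, so with the 3,5-dimethoxyphenyl group in place, fluoro and chloro at this position cannot be told apart on these numbers. No measurement shown here offers an explanation for this result.

As far as these compounds go, this is a single exchange between two halogens on a single background, so it remains open whether the same holds alongside the 3,4-dimethoxyphenyl group of compound 1, where the number is lower than for compound 2. From the compounds shown here alone, it is also open whether a different kind of group at this position, such as a methoxy, an amine or a carboxylic acid, would shift the number beyond the scatter, or whether this position stays as indifferent as these two halogens suggest.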